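The compounds below may be only part of what the source reports. "The series", "measured", "known", "first", "only" and "open" are said of these compounds alone.

Measured compounds in the series:
- compound 1, `COC(=O)c1ccc(NCc2cncn2Cc2ccccc2N)cc1-c1ccccc1`: 25000 nM
- compound 2, `COC(=O)c1ccc(NCc2cncn2Cc2ccc(F)cc2F)cc1-c1ccccc1`: > 1000 nM
- compound 3, `COC(=O)c1ccc(NCc2cncn2Cc2cccc(OC)c2)cc1-c1ccccc1`: "not determined" (no result reported)

In a toxicity assay on NIH3T3 cells (Mus musculus) for cytotoxicity, read by resazurin assay (on this read-out higher numbers stand for an effect only at larger amounts of compound and lower numbers for an effect already at smaller amounts), compound 1 gives 25000 nM. For compound 2 the result in this assay is a limit only, > 1000 nM, not a number. The step from compound 1 to compound 2 is therefore a step that the limit leaves unreadable from compound 1 to compound 2; its size cannot be read because of the limit of > 1000 nM in this assay, at which 1 of the 3 values shown sits. Compound 3, which differs from the others only in the group on the saturated chain carbon bound to the aromatic nitrogen, carries no result in this assay at all, so it stands nowhere on the numbers shown, and the only other value in the set besides compound 1 is the limit.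

Compound 4, `COC(=O)c1ccc(NCc2cncn2Cc2ccccc2[N+](=O)[O-])cc1-c1ccccc1`, has not been measured in this assay. Against compound 3 the change is 2-nitrophenyl in place of 3-methoxyphenyl on a saturated chain carbon bound to an aromatic nitrogen. Going by the values given here, no measured step in this assay bears directly on this change: the one step available is unreadable, and compound 3 has no number to step from. What can be said is that the one numeric result, for compound 1, lies far up the scale, and the limit for compound 2 does not contradict a similarly high value. Compound 4 is therefore expected to give about 20000 nM in this assay, in the range 5000 nM to 60000 nM, with a fair chance that only a limit is reported.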

Compound 4, half-maximal effective concentration: 10000 nM
Estimate against measurement, compound 4: 2.0-fold (0.30 log units) above; the range from low to high includes it.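

In this assay, the group on the saturated chain carbon bound to an aromatic nitrogen now gives its first readable step: a 2.5-fold lower number from compound 1 to compound 4 (0.40 log units; beyond the scatter), with nitro in place of amino on an aromatic carbon. The step is modest but beyond the usual scatter, so this single exchange on the aromatic carbon is enough to move the read-out, here towards an effect at smaller amounts of compound. The steps involving compound 2 cannot be read, as compound 2 carries only a limit, so 2,4-difluorophenyl cannot be ranked against 2-aminophenyl or 2-nitrophenyl: the limit of > 1000 nM in this assay, at which 1 of the 4 values shown sits.

Compound 3 stands at "not determined" (no result reported), which leaves 3-methoxyphenyl without a place on the scale of this assay and gives no reading of how the 3-methoxybenzyl and 2-nitrobenzyl groups compare. Also open, going by these compounds, is whether the step from amino to nitro is part of a wider trend on that aromatic carbon, which a hydroxyl group, a nitrile or an acetamide there would test.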